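Swapping a Pyridylmethyl Arm for a Pyridyl Ring

The source may hold more compounds than are shown below. What is called first, only, known or untested is meant among the compounds shown, and "the series" means these compounds.

Measured compounds:
- compound 1 `Nc1ccccc1NC(=O)c1ccc(CSC(=S)N2CCN(Cc3ccncc3)CC2)cc1`: 33.1%
- compound 2 `Cc1ccc(N2CCN(C(=S)SCc3ccc(C(=O)Nc4ccccc4N)cc3)CC2)cc1`: 25.8%
- compound 3 `Nc1ccccc1NC(=O)c1ccc(CSC(=S)N2CCN(Cc3cccnc3)CC2)cc1`: 31.5%

All three share one core and differ only in the group on an amine nitrogen in a ring. In a functional assay on A-375 cells (Homo sapiens) for antiproliferative activity, read by CCK-8 assay, with a stated time of 72 h, tested at 2 uM (on this read-out higher numbers stand for a stronger effect at the one concentration tested and lower numbers for a weaker effect), compound 3 gives 31.5%, the second highest of the three numbers, although none of the three stands apart from the others beyond the scatter: the step of a number 1.6 percentage points lower from compound 1 to compound 3 (within the scatter) and the step of a number 5.7 percentage points higher from compound 2 to compound 3 (within the scatter) are both small.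

Compound 4 `Nc1ccccc1NC(=O)c1ccc(CSC(=S)N2CCN(c3ccncc3)CC2)cc1` has not yet been measured. It differs from compound 3 in one place: pyridin-4-yl in place of (pyridin-3-yl)methyl on an amine nitrogen in a ring. The ring is now attached directly to the ring nitrogen rather than through a one-carbon link.

Among the compounds with values here, the closest precedent is the step of a number 7.3 percentage points lower from compound 1 to compound 2 (within the scatter), where a directly attached six-membered aromatic ring also replaced a ring joined through one carbon; that change gave a small loss, within the scatter. The step of a number 1.6 percentage points lower from compound 1 to compound 3 (within the scatter) shows that moving the nitrogen within the pyridine ring barely matters. Taken together, a small downward drift or no step beyond the scatter is expected in this assay, so that for compound 4 the estimated step is a number 3.5 percentage points lower from compound 3 to compound 4 (within the scatter). Compound 4 is therefore expected to give about 28%, with a likely range from 16% to 40%.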

Compound 4, a percentage reported as inhibition, at one concentration (the size of the read-out at that concentration, not a potency): 85.7%
The estimate for compound 4 lay 57.7 percentage points below the measured number, outside the stated range (above it).
By their numbers in this assay, from the lowest: compounds 2, 3 and 1 (each within the scatter of the next); then compound 4.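

In this assay, within the data shown here, the group on the amine nitrogen in a ring proves to matter far more than the earlier compounds suggested: pyridin-4-yl in place of (pyridin-3-yl)methyl gives a number 54.2 percentage points higher from compound 3 to compound 4 (beyond the scatter), and pyridin-4-yl in place of (pyridin-4-yl)methyl gives a number 52.6 percentage points higher from compound 1 to compound 4 (beyond the scatter). A directly attached six-membered aromatic ring is not enough on its own, since pyridin-4-yl in place of 4-methylphenyl still gives a number 59.9 percentage points higher from compound 2 to compound 4 (beyond the scatter). Among these four compounds, neither a pyridine ring held through one carbon, as in compound 1 and compound 3, nor a directly attached ring with no hetero atom, as in compound 2, reaches the level of compound 4, which has the pyridine ring attached directly.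

From the compounds shown here alone, whether this high level also holds for a directly attached pyridin-3-yl or pyridin-2-yl, or for an unsubstituted phenyl ring, remains open, and a single concentration in one cell line cannot show how far the effect extends. Nothing in the available data accounts for the size of this jump.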